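Adding a second fluoro to a compound at the limit

A few compounds are considered here, and "the series" means these few. Any claim that something is new, unique, unknown or untested is made for them only; others in the source may bear on it.

Measured in a functional assay on HepG2 cells (Homo sapiens) for cytotoxicity, with a stated time of 72 h; a higher number here means that more compound is needed for the effect, a lower number that less compound is needed:
Compound 1 `C=C[C@@](C)(/C=C/c1ccc(OCc2ccccc2)cc1)CCC=C(C)C`: > 52000 nM
Compound 2 `C=C[C@@](C)(/C=C/c1ccc(Nc2ccc(F)cc2)cc1)CCC=C(C)C`: > 52000 nM

Compound 2 gives > 52000 nM in this assay and this is a limit, not a number. The record so far is the limit of > 52000 nM in this assay, at which 2 of the 2 values shown sit, and it holds no readable number.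

Compound 3 `C=C[C@@](C)(/C=C/c1ccc(Nc2ccc(F)c(F)c2)cc1)CCC=C(C)C` takes fluoro in place of hydrogen on an aromatic carbon, ortho to a fluoro group and meta to a large group (fluoro in place of hydrogen on an aromatic carbon), so (4-fluorophenyl)amino becomes (3,4-difluorophenyl)amino. Among the compounds with values here, the only measured step available is a step that the two limits leave unreadable from compound 1 to compound 2 and it offers no size to carry over. No move beyond the scatter is therefore foreseen in this assay in either direction, and the expected change is a number no higher from compound 2 to compound 3 (the limit leaves the size open) as an estimate only. Compound 3 is estimated at 52000 nM with an expected range from 25000 nM to 100000 nM and may well turn out to be only a limit.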

Compound 3, half-maximal effective concentration: > 52000 nM
Compound 3 gave a limit, no number; the forecaster's own chance of this, stated with the estimate: 75%; the middle value sits exactly at the limit.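

In this assay compound 3 gives > 52000 nM, a limit and not a number. The steps from compound 1 and from compound 2 to compound 3 therefore cannot be read: the limit of > 52000 nM in this assay, at which 3 of the 3 values shown sit.

The compounds shown leave open where any of them would give a readable number in this assay, and whether the added fluoro changes it at all.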